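Phenyl to Naphthalen-1-yl at the Aromatic Carbon

The compounds below may be only part of what the source reports. "The series", "measured", "known", "first", "only" and "open" are said of these compounds alone.

Compound 3 `COc1cccc(CNCCCNc2ccnc3cc(-c4ccccc4)ccc23)c1O` gives 9.47 in a physicochemical assay for acid dissociation, while compound 1 `COc1cccc(Oc2ccc3c(NCCCNCc4cccc(OC)c4O)ccnc3c2)c1` gives 9.28 and compound 2 `COc1cccc(CNCCCNc2ccnc3cc(Oc4ccc(F)cc4)ccc23)c1O` gives 9.28, both within the scatter of compound 3. Compound 4 `COc1cccc(CNCCCNc2ccnc3cc(-c4cccc5ccccc45)ccc23)c1O` differs from compound 3 in one place: naphthalen-1-yl in place of phenyl on an aromatic carbon. Within the data shown here, the steps that bear on this change are exchanges on the same aromatic carbon, a number 0.19 log units higher from compound 1 to compound 3 (within the scatter) and a number 0.19 log units higher from compound 2 to compound 3 (within the scatter), together with the exchange on the oxygen, no change at the digits printed from compound 1 to compound 2 (within the scatter); none of them moved this assay beyond the scatter. Putting naphthalen-1-yl in place of phenyl is therefore expected to leave this assay essentially unchanged, with a number 0.02 log units lower from compound 3 to compound 4 (within the scatter). Compound 4 is estimated at 9.45, expected to fall between 9.15 and 9.75.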

Compound 4, acid dissociation constant: 9.47
Compound 4: middle estimate off by 0.02 log units, on the low side; measured number inside the range.
By their numbers in this assay, from the lowest: compounds 1, 2, 3 and 4 (each within the scatter of the next).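

In this assay, naphthalen-1-yl in place of phenyl on this aromatic carbon, which adds a second six-membered aromatic ring of carbon only, gives no change at the digits printed from compound 3 to compound 4 (within the scatter). Exchanging the oxygen-linked groups for naphthalen-1-yl reads the same way, with a number 0.19 log units higher from compound 2 to compound 4 (within the scatter) and a number 0.19 log units higher from compound 1 to compound 4 (within the scatter), so all four groups seen at this place lie within the scatter of one another. No measured evidence accounts for this result. On these data alone, whether an amine or a carboxylic acid on this aromatic carbon would move this assay beyond the scatter remains open, as does the effect of a longer chain elsewhere on the shared core.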